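This account rests on a few compounds, and the source may have more. Where it says the series, first, only, none or still open, it means among the compounds named here.

Measured so far in a functional assay on the whole organism (strain Wistar) for inhibition, with Rattus norvegicus as the target, read by paw edema, with stated times of 60 min and 2 h, at a dose of 100 mg/kg by the oral route; on this read-out higher numbers stand for more inhibition at the one dose given (going by the name of the read-out) and lower numbers for less inhibition:
compound 1 `CCCCCNC(=O)CC1CCc2cc(OC)c(OC)cc21` gives 34%;
compound 2 `CCCCCCNC(=O)CC1CCc2cc(OC)c(OC)cc21` gives 41.5%;
compound 3 `COc1cc2c(cc1OC)C(CC(=O)NC1CCCCC1)CC2` gives 56%.

Compound 3 stands highest of the three numbers in this assay: a number 14.5 percentage points higher from compound 2 to compound 3 (beyond the scatter) and a number 22 percentage points higher from compound 1 to compound 3 (beyond the scatter), both beyond the scatter, while a number 7.5 percentage points higher from compound 1 to compound 2 (within the scatter) lies within it. Compound 4 `COc1cc2c(cc1OC)C(CC(=O)N1CCCCC1)CC2` differs from compound 3 by piperidin-1-yl in place of cyclohexylamino on a carbonyl carbon. Among the compounds with values here, the two measured steps that reach compound 3 each exchange an open chain for a carbon ring on the amide-type nitrogen; no measured step exchanges cyclohexylamino for piperidin-1-yl, so none bears directly on this change. The step of a number 10 percentage points lower from compound 3 to compound 4 (within the scatter) is therefore expected to be small, within the scatter, with wide uncertainty. Compound 4 is expected to give 46%, in the range 26% to 66%.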

Compound 4, a percentage reported as inhibition, in the whole organism at one dose (the size of the read-out at that dose, not a potency): 22%
Beside the measured number, compound 4's estimate is 24 percentage points above it; measured number outside the range, below it.
By their numbers in this assay, from the lowest: compound 4; then compounds 1 and 2 (each within the scatter of the next); then compound 3.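

On a carbonyl carbon, piperidin-1-yl in place of cyclohexylamino, which removes the amide hydrogen, brings in this assay a clear fall: a number 34 percentage points lower from compound 3 to compound 4 (beyond the scatter) against the rises seen on going from the open chains to cyclohexylamino. A six-membered ring on the amide-type nitrogen therefore does not by itself raise the number, and the open chains also stand higher, with a number 19.5 percentage points lower from compound 2 to compound 4 (beyond the scatter) and a number 12 percentage points lower from compound 1 to compound 4 (beyond the scatter) for the same kind of exchange.

From the compounds shown here alone, whether the amide hydrogen or the way the ring is attached matters remains open; methyl(cyclohexyl)amino and pyrrolidin-1-yl on this carbonyl carbon would help separate the two. No measurement at hand accounts for the fall.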